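From 2-fluorophenyl to 2,6-dichlorophenyl: an expected tolerance

A few compounds are considered here, and "the series" means these few. Any claim that something is new, unique, unknown or untested is made for them only; others in the source may bear on it.

Measured in an ADME assay on cells (Peritoneal macrophage cell, Mus musculus) for cytotoxicity, read by fluorescence and resazurin assay, with a stated time of 3 days; a lower number here means that less compound is tolerated, a higher number that more compound is tolerated:
- Compound 1 `O=C(NCc1ccccc1)Nc1[nH]nc(-c2ccccn2)c1Cl`: > 64000 nM
- Compound 2 `O=C(Nc1[nH]nc(-c2ccccn2)c1C1CC1)c1ccccc1F`: > 64000 nM
- Compound 3 `N#Cc1ccc(OC2CCN(C(=O)Nc3cc(-c4ccccn4)n[nH]3)CC2)cc1`: > 64000 nM

Each of these values is a limit of the assay and not a number. Compound 2 gives > 64000 nM, which is such a limit. Across the three compounds, the data show (the limit of > 64000 nM in this assay, at which 3 of the 3 values shown sit). Compound 4 `O=C(Nc1[nH]nc(-c2ccccn2)c1C1CC1)c1c(Cl)cccc1Cl` carries 2,6-dichlorophenyl in place of 2-fluorophenyl on a carbonyl carbon. Within the data shown here, no two measured compounds differ in only one place, so the data give no step size to draw on. In this assay, no change beyond the usual scatter is expected, and any small shift is expected to be toward less compound tolerated. The estimated change is an at least 1.0-fold lower number from compound 2 to compound 4 (0.02 log units; that floor lies within the scatter). Compound 4 is expected to read 60000 nM, with an estimated range of 25000 nM to 64000 nM.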

Compound 4, half-maximal cytotoxic concentration: > 64000 nM
Compound 4 ended at the assay's limit (the forecaster's own chance of this, stated with the estimate: 65%); middle value at least 1.0-fold (0.02 log units) away from the limit.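

Among these compounds, compound 2 and compound 4 both read as limits of the assay, not as numbers, and no step between them can be read. The compounds shown leave open what concentration of any of them would harm these cells, with a single reading throughout: the limit of > 64000 nM in this assay, at which 4 of the 4 values shown sit.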